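Fluorine on the Benzylamine of a Weak Quinoline Amide

The source may report more compounds than this note shows. Statements on the series, on what has been measured and on what is new or still open speak of the compounds shown alone.

Compounds measured:
- compound 1 `O=C(NCc1ccc(F)cc1)c1nc(Br)c2cccnc2c1NCc1ccccc1`: > 20000 nM
- compound 2 `N[C@H]1CC[C@H](Nc2c(C(=O)Nc3ccccc3)nc(Br)c3cccnc23)CC1`: 1000 nM
- compound 3 `N[C@H]1CC[C@H](Nc2c(C(=O)NCc3ccc(F)cc3)nc(N3CCCCS3(=O)=O)c3cccnc23)CC1`: 5000 nM

In a functional assay on MDA-MB-435 cells (Homo sapiens) for cytotoxicity, read by MTT assay, with a stated time of 72 h (on this read-out lower numbers stand for stronger inhibition and higher numbers for weaker inhibition), compound 1 gives only a limit, > 20000 nM, not a number. In this assay compound 2 gives 1000 nM and compound 3 gives 5000 nM; both carry an aminocyclohexyl group in place of the benzylamine of compound 1, so neither pair forms a single change. Compound 1 sits at the weak end of what is shown, as the limit of > 20000 nM in this assay, at which 1 of the 3 values shown sits, states.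

Compound 4 `O=C(NCc1ccc(F)cc1)c1nc(Br)c2cccnc2c1NCc1ccc(F)cc1` differs from compound 1 by fluoro in place of hydrogen on an aromatic carbon. Among the measured compounds shown here, a single fluoro in place of hydrogen is a small change, and no step in the set speaks to it. The estimate for compound 4 is 30000 nM (range 8000 nM to 100000 nM), a step that the limit leaves unreadable from compound 1 to compound 4 that is expected to stay within the scatter, most likely again reported as a limit.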

Compound 4, half-maximal inhibitory concentration: > 20000 nM
Compound 4: only a limit was reported; the forecaster's own chance of this, stated with the estimate: 75%; the middle value lies beyond the limit too.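

In this assay compound 4 gives > 20000 nM, which is a limit and not a number. Compound 1 also gives only a limit, so no step can be read between compound 1 and compound 4. As far as these compounds go, whether benzyl to 4-fluorobenzyl changes activity at all remains open.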